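The compounds below may be only part of what the source reports. "The series", "measured", "known", "first", "only" and "open" are said of these compounds alone.

Working notes on the series. Going by the values given here, in a functional assay on the whole organism (Tail, strain ICR) with Mus musculus as the target, in the tail flick test, with a stated time of 150 min, at a dose of 25 umol/kg by the oral route (on this read-out lower numbers stand for a weaker effect and higher numbers for a stronger effect at the one dose given), compound 3 `C[C@@H](O)[C@H](NC(=O)CN(c1nc(Cl)nc2[nH]cnc12)C1CC1)C(=O)OCc1ccccc1` gives 12.8%, the second highest of the three numbers so far. Its nearest neighbour is compound 2 `O=C(CN(c1nc(Cl)nc2[nH]cnc12)C1CC1)NCC(=O)OCc1ccccc1`, which in this assay gives 18%; the step of a number 5.2 percentage points lower from compound 2 to compound 3 (within the scatter) stays within the scatter. Furthest is compound 1 `O=C(CN(c1nc(Cl)nc2[nH]cnc12)C1CC1)N[C@@H](CC(=O)OCc1ccccc1)C(=O)OCc1ccccc1`, which in this assay gives 6.68%; the step of a number 6.1 percentage points higher from compound 1 to compound 3 (within the scatter) is also within the scatter. Among the compounds with values here, the only step beyond the scatter is a number 11.3 percentage points higher from compound 1 to compound 2 (beyond the scatter), a modest one.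

Compound 4 `O=C(CN(c1nc(Cl)nc2[nH]cnc12)C1CC1)N[C@@H](CO)C(=O)OCc1ccccc1` differs from compound 3 by hydrogen in place of methyl on a saturated chain carbon bound to an oxygen on a saturated carbon and a saturated chain carbon. Within the data shown here, no measured step touches this position: all three measured steps alter the saturated chain carbon bound to an amide-type nitrogen and a carbonyl carbon, and two of them fall within the scatter. Loss of a methyl at the hydroxyl-bearing carbon gives no basis for expecting a step beyond the scatter in either direction in this assay.

Compound 4 is therefore expected to give about 13% in this assay, within 3% to 25%. The expected step is a number 0.2 percentage points higher from compound 3 to compound 4 (within the scatter).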

Compound 4, a percentage reported as activity, at one dose (the size of the read-out at that dose, not a potency): 27.9%
For compound 4 the middle estimate is 14.9 percentage points below the measured one; the measured number lies above the stated range.
By their numbers in this assay, from the lowest: compounds 1, 3, 2 and 4 (each within the scatter of the next, the first and the last beyond it).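

In this assay, going by these compounds alone, the saturated chain carbon bound to an oxygen on a saturated carbon and a saturated chain carbon proves responsive: 1-hydroxyethyl to hydroxymethyl gives a number 15.1 percentage points higher from compound 3 to compound 4 (beyond the scatter) as the first step beyond the scatter outside the carbon bound to an amide-type nitrogen and a carbonyl carbon. Hydroxymethyl in place of hydrogen gives a number 9.9 percentage points higher from compound 2 to compound 4 (within the scatter) and so does not separate that pair, whereas hydroxy in place of benzyloxycarbonyl gives a number 21.2 percentage points higher from compound 1 to compound 4 (beyond the scatter) as the largest step in the series. No evidence at hand accounts for the effect of losing this methyl.

Still open, from the compounds shown here alone, is how an aminomethyl, a methoxymethyl or a longer chain such as 2-hydroxyethyl would read in place of the hydroxymethyl. Also open, going by these compounds, is whether a carboxylic acid in place of the benzyl ester would preserve the step.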